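Cytotoxicity notes on compounds 1 to 4

The source may hold more compounds than are shown below. What is called first, only, known or untested is meant among the compounds shown, and "the series" means these compounds.

Values in an ADME assay on PBMC cells (Homo sapiens) for cytotoxicity, read by trypan blue exclusion, with a stated time of 6 days; on this read-out higher numbers stand for lower toxicity in this test and lower numbers for higher toxicity in this test:
compound 1 `COc1nc(ONC(=O)OCc2ccccc2)nc2c1ncn2[C@@H]1O[C@H](CO)[C@@H](O)[C@@]1(C)O`: > 100000 nM, a limit
compound 2 `COc1nc(O)nc2c1ncn2[C@@H]1O[C@H](CO)[C@@H](O)[C@@]1(C)O`: > 100000 nM, a limit
compound 3 `COc1nc(OC)c2ncn([C@@H]3O[C@H](CO)[C@@H](O)[C@@]3(C)O)c2n1`: > 100000 nM, a limit

Compound 1 stands at the limit of this assay, and the two other measured compounds stand at the same limit; all three sit at the limit of > 100000 nM in this assay, at which 3 of the 3 values shown sit. The steps a step that the two limits leave unreadable from compound 1 to compound 2 and a step that the two limits leave unreadable from compound 1 to compound 3 are accordingly not readable in size, nor is a step that the two limits leave unreadable from compound 2 to compound 3. Compound 4 `C[C@@]1(O)[C@H](O)[C@@H](CO)O[C@H]1n1cnc2c(N)nc(ONC(=O)OCc3ccccc3)nc21` differs from compound 1 by amino in place of methoxy on an aromatic carbon. Among the measured compounds shown here, none of the measured steps touches that position, and none of them yields a readable size, so no measured step bears on this change in a usable way; what the series shows is only that every variation so far has stayed at the limit. Compound 4 is therefore expected to give a value at or beyond the same limit, the expected step being a step that the limit leaves unreadable from compound 1 to compound 4, that is none beyond the scatter. The estimate for compound 4 in this assay is 150000 nM, with a range of 50000 nM to 500000 nM.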

Compound 4, half-maximal cytotoxic concentration: > 100000 nM
Compound 4: no number, only a limit; the forecaster's own chance of this, stated with the estimate: 85%; the middle value lies beyond the limit too.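

In this assay compound 4 gives > 100000 nM, which is a limit. The step between compound 1 and compound 4 cannot be read because both values are limits: the limit of > 100000 nM in this assay, at which 4 of the 4 values shown sit. The compounds shown leave open what actual half-maximal cytotoxic concentration any of compounds 1 to 4 has, and so whether their substituents differ in effect.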